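Replacing pyridazin-4-yl with 3-chlorophenyl in compound 3

This account rests on a few compounds, and the source may have more. Where it says the series, first, only, none or still open, it means among the compounds named here.

Compound 1 `O=C(Nc1ccnnc1)c1cc(C(F)(F)F)ccc1OCc1ccccc1`: < 1000 nM
Compound 2 `O=C(Nc1ccnnc1)c1cc(N2C[C@H]3COC[C@H]3C2)ccc1OCc1ccccc1`: 57000 nM

In a physicochemical assay for solubility, measured as kinetic solubility (on this read-out higher numbers stand for higher solubility and lower numbers for lower solubility), compound 1 is reported only as a limit, < 1000 nM, and not as a number. Compound 3 `O=C(Nc1cccc(Cl)c1)c1cc(C(F)(F)F)ccc1OCc1ccccc1` keeps the core of compound 1 and differs by 3-chlorophenyl in place of pyridazin-4-yl on an amide-type nitrogen. Among the measured compounds shown here, the only measured step, an at least 57-fold higher number from compound 1 to compound 2 (1.75 log units; beyond the scatter), was large, but it replaced the trifluoromethyl on an aromatic carbon, a group that compound 3 keeps. No rise of that size is therefore expected in this assay, and the number should stay low. The estimated step is a step that the limit leaves unreadable from compound 1 to compound 3. Compound 3 is expected at 400 nM, within 80 nM to 1500 nM.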

Compound 3, solubility: 7000 nM
Compound 3: the middle estimate sits 18-fold (1.24 log units) below what was measured, and the stated range ends below it.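

With the trifluoromethyl kept, the change on the amide-type nitrogen alone gives, in this assay, an at least 7.0-fold higher number from compound 1 to compound 3 (0.84 log units; beyond the scatter). The read-out therefore responds at this position as well, and not only at the aromatic carbon changed in compound 2. Compound 1 is held only at a limit, so the full size of this step stays unknown: the limit of < 1000 nM in this assay, at which 1 of the 3 values shown sits.

The compounds shown leave open whether plain phenyl or pyridin-3-yl on that nitrogen would behave like 3-chlorophenyl. They also leave open how 3-chlorophenyl behaves together with the group that compound 2 carries in place of trifluoromethyl.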